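Removing the amino group from compound 3

The source may hold more compounds than are shown below. What is called first, only, known or untested is meant among the compounds shown, and "the series" means these compounds.

compound 1 `Cc1ccc(C#Cc2c([N+](=O)[O-])nc3n2CC(C)O3)cc1` gives 5470 nM
compound 2 `COc1cccc(C#Cc2c([N+](=O)[O-])nc3n2CC(C)O3)c1` gives 12900 nM
compound 3 `CC1Cn2c(nc([N+](=O)[O-])c2C#Cc2cccc(N)c2)O1` gives 18100 nM

In an ADME assay on CHO cells (Cricetulus griseus) for cytotoxicity, read by MTT assay, with a stated time of 24 h (on this read-out higher numbers stand for lower toxicity in this test and lower numbers for higher toxicity in this test), compound 3 (18100 nM) sits at the upper end of the three numbers. The gap to the methoxy analogue is small (a 1.4-fold higher number from compound 2 to compound 3 (0.15 log units; within the scatter)), and the gap to the 4-methylphenyl analogue is larger (a 3.3-fold higher number from compound 1 to compound 3 (0.52 log units; beyond the scatter)).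

Compound 4 `CC1Cn2c(nc([N+](=O)[O-])c2C#Cc2ccccc2)O1` is the next case, with hydrogen in place of amino on an aromatic carbon, so 3-aminophenyl becomes phenyl. Among the measured compounds shown here, no measured step makes this exact change, and no measured compound carries a plain phenyl. The two steps that end at the amino compound are the nearest evidence. Read in reverse, both point toward a lower number without the amino group, but only the one from the 4-methylphenyl analogue (a 3.3-fold higher number from compound 1 to compound 3 (0.52 log units; beyond the scatter)) lies beyond the scatter, and it also changes more than the amino group. The methoxy comparison (a 1.4-fold higher number from compound 2 to compound 3 (0.15 log units; within the scatter)) stays within it. A small move toward a lower number is therefore expected in this assay, probably not beyond the scatter, and the estimate is a step of this kind (a 1.8-fold lower number from compound 3 to compound 4 (0.26 log units; within the scatter)). For compound 4 the expected value is 10000 nM (estimated range 4500 nM to 22000 nM).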

Compound 4, half-maximal cytotoxic concentration: 3540 nM
Compound 4: the middle estimate sits 2.8-fold (0.45 log units) above what was measured, outside the stated range (below it).
By their numbers in this assay, from the lowest: compounds 4 and 1 (each within the scatter of the next); then compounds 2 and 3 (each within the scatter of the next).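

In this assay, among the compounds shown here, the plain phenyl of compound 4 shows that this position matters more than the earlier compounds suggested: hydrogen in place of amino gives the largest step so far (a 5.1-fold lower number from compound 3 to compound 4 (0.71 log units; beyond the scatter)). Hydrogen in place of methoxy moves the same way (a 3.6-fold lower number from compound 2 to compound 4 (0.56 log units; beyond the scatter)), while hydrogen in place of methyl does not separate the two compounds (a 1.5-fold lower number from compound 1 to compound 4 (0.19 log units; within the scatter)). Among these four compounds, compound 2 and compound 3 therefore stand together at the higher numbers and compound 1 and compound 4 at the lower, a split the first three compounds could not show without an unsubstituted ring as reference.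

Nothing available explains this split. As far as these compounds go, whether a hydroxyl group, a dimethylamino group or a carboxylic acid on the same aromatic carbon would stand with compound 3 or with compound 4 stays open, as does whether the amino group would keep the higher number at the ring position held by methyl in compound 1.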